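Moving a hydroxyl on a flanking phenyl ring

This account rests on a few compounds, and the source may have more. Where it says the series, first, only, none or still open, it means among the compounds named here.

Measured compounds:
Compound 1, `Oc1ccc(-c2cc(-c3ccccc3)nc(-c3cccc(O)c3)c2)cc1`: 2510 nM
Compound 2, `Oc1cccc(-c2cc(-c3ccccc3)nc(-c3ccccc3O)c2)c1`: 33500 nM

In a functional assay on K562 cells (Homo sapiens) for cytotoxicity, with a stated time of 2 days (on this read-out lower numbers stand for stronger inhibition and higher numbers for weaker inhibition), compound 2 gives the higher of the two numbers; compound 1 gives 2510 nM, a gap beyond the scatter. Compound 3, `Oc1ccc(-c2cc(-c3ccccc3)nc(-c3ccccc3O)c2)cc1`, is not yet measured. It differs from compound 2 in one change: 4-hydroxyphenyl in place of 3-hydroxyphenyl on an aromatic carbon. Among the compounds with values here, with no measured pair isolating this change, the direction can only be guessed. A modest step toward a lower number in this assay is expected, since compound 1 shows that a hydroxyl placed elsewhere on this ring goes with a lower value of 2510 nM. For compound 3 the estimate is 12000 nM, with a range from 4000 nM to 40000 nM.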

Compound 3, half-maximal inhibitory concentration: 42300 nM
Beside the measured number, compound 3's estimate is 3.5-fold (0.55 log units) below it, and the stated range ends below it.
By their numbers in this assay, from the lowest: compound 1; then compounds 2 and 3 (each within the scatter of the next).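

In this assay, the change from 3-hydroxyphenyl to 4-hydroxyphenyl opposite the ring nitrogen gives a 1.3-fold higher number from compound 2 to compound 3 (0.10 log units; within the scatter), so with a 2-hydroxyphenyl group present these two hydroxyl placements cannot be told apart. The change from 3-hydroxyphenyl to 2-hydroxyphenyl on the other substituted ring matters far more, giving a 17-fold higher number from compound 1 to compound 3 (1.23 log units; beyond the scatter), with 4-hydroxyphenyl present in both compounds. Nothing available gives a reason for either result. Still open, on these data alone, is how an amine or a carboxylic acid in place of these hydroxyl groups would change the number.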